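Phenyl group change from compound 3 to compound 4

The compounds below may be only part of what the source reports. "The series", "measured", "known", "first", "only" and "open" are said of these compounds alone.

Measured in a functional assay on HL-60 cells (Homo sapiens) for inhibition, read by MTT assay, with a stated time of 72 h; a higher number here means a weaker inhibitor, a lower number a stronger inhibitor:
- compound 1 `CCc1nc(-c2ccccc2F)c(C(=O)N2CCN(c3cccc(Cl)c3)CC2)o1`: 139 nM
- compound 2 `Cc1nc(-c2cccc(F)c2)c(C(=O)N2CCN(c3cccc(Cl)c3)CC2)o1`: 33.7 nM
- compound 3 `CCc1nc(-c2ccccc2Cl)c(C(=O)N2CCN(c3cccc(Cl)c3)CC2)o1`: 98.9 nM

Compound 3 stands within the scatter of compound 1 and beyond the scatter above compound 2. Compound 4 `CCc1nc(-c2cccc(F)c2)c(C(=O)N2CCN(c3cccc(Cl)c3)CC2)o1` carries 3-fluorophenyl in place of 2-chlorophenyl on an aromatic carbon. Within the data shown here, the one measured step, chloro in place of fluoro, gives a 1.4-fold lower number from compound 1 to compound 3 (0.15 log units; within the scatter), so that halogen swap alone shows no shift. The nearest evidence is compound 2, which bears 3-fluorophenyl with methyl instead of ethyl, at 33.7 nM. Among the measured compounds shown here, no measured pair shows the methyl-to-ethyl change. A lower number is therefore expected, with a 2.2-fold lower number from compound 3 to compound 4 (0.34 log units; beyond the scatter) as the estimated step. For compound 4 the estimate is 45 nM, with an expected range of 20 nM to 100 nM.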

Compound 4, half-maximal inhibitory concentration: 317 nM
For compound 4 the middle estimate is 7.0-fold (0.85 log units) below the measured one, outside the stated range (above it).
By their numbers in this assay, from the lowest: compound 2; then compounds 3 and 1 (each within the scatter of the next); then compound 4.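

In this assay, 3-fluorophenyl on this aromatic carbon gives a weaker inhibitor than either 2-halophenyl partner with ethyl: a 3.2-fold higher number from compound 3 to compound 4 (0.51 log units; beyond the scatter) and a 2.3-fold higher number from compound 1 to compound 4 (0.36 log units; beyond the scatter). The largest step comes with the chain change at fixed 3-fluorophenyl, a 9.4-fold higher number from compound 2 to compound 4 (0.97 log units; beyond the scatter), so the low number of the methyl compound does not carry over to ethyl. No measurement here accounts for this.

As far as these compounds go, whether 2-chlorophenyl or 2-fluorophenyl also prefers methyl over ethyl stays open. So does the reading of a propyl chain or an aminomethyl group in that place.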